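Swapping a Pyrazole Substituent and Its Effect on Solubility

The compounds below may be only part of what the source reports. "The series", "measured", "known", "first", "only" and "open" are said of these compounds alone.

Of the compounds shown here, three that share one fused core have been measured for a physicochemical assay for solubility, in simulated intestinal fluid; on this read-out lower numbers stand for lower solubility and higher numbers for higher solubility. Compound 1 `Cn1cc(-c2nc3c(-c4ccc(CNC(=O)c5nc(C(C)(C)C)no5)c(F)c4)ccnc3[nH]2)cn1` gives 2 ug/mL, compound 3 `Cc1c(-c2nc3c(-c4ccc5c(c4)CCC[C@H]5NC(=O)c4nc(C(C)(C)C)no4)ccnc3[nH]2)cnn1C1CCOCC1` gives 7 ug/mL, and compound 2 `Cn1cc(-c2nc3c(-c4ccc5c(c4)CCC[C@@H]5NC(=O)c4nc(C(C)(C)C)no4)ccnc3[nH]2)cn1` gives 190 ug/mL. Compound 2 therefore stands highest of the three in this assay: its number lies well above that of compound 3, and further still above that of compound 1, both gaps being beyond the usual scatter.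

Compound 4 `Cc1c(-c2nc3c(-c4ccc5c(c4)CCC[C@@H]5NC(=O)c4nc(C(C)(C)C)no4)ccnc3[nH]2)cnn1C(C)C` has not yet been measured. It is built from compound 2 by a single change: 1-isopropyl-5-methyl-1H-pyrazol-4-yl in place of 1-methyl-1H-pyrazol-4-yl on an aromatic carbon. Going by the values given here, no pair of measured compounds differs by exactly this change, so the step can only be anticipated. Among the compounds with values here, compound 3 also carries a more substituted pyrazole than the one in compound 2, and compound 3 gives 7 ug/mL, which points toward a drop. The step from compound 2 to compound 4 is expected to be a clear fall, roughly a 9.5-fold lower number from compound 2 to compound 4 (0.98 log units; beyond the scatter). Compound 4 is accordingly estimated at 20 ug/mL, within a range from 5 ug/mL to 80 ug/mL.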

Compound 4, solubility: 28 ug/mL
Compound 4: the middle estimate sits 1.4-fold (0.15 log units) below what was measured, within the range that was stated.
By their numbers in this assay, from the lowest: compound 1; then compound 3; then compound 4; then compound 2.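

In this assay, going by these compounds alone, putting 1-isopropyl-5-methyl-1H-pyrazol-4-yl in place of 1-methyl-1H-pyrazol-4-yl gives a 6.8-fold lower number from compound 2 to compound 4 (0.83 log units; beyond the scatter), the first direct reading of a change at this aromatic carbon with the rest of the molecule held constant. The two groups share one five-membered aromatic ring and have the same nitrogen, hydrogen-bond donor and acceptor counts and no net charge, while the carbon count rises from 4 to 7. Nothing measured here explains why the number falls.

Going by these compounds, the isopropyl and the added methyl enter together, so the share of each in this step remains unknown. On these data alone, how a pyrazole bearing an amine or a carboxylic acid would read in this assay also remains open.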